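The source may hold more compounds than are shown below. What is called first, only, known or untested is meant among the compounds shown, and "the series" means these compounds.

Of the compounds shown here, three built on the same core have so far been tested in a functional assay on B16-F10 cells (Mus musculus) for inhibition, read by MTT assay, with a stated time of 72 h; a higher number here means a weaker inhibitor, a lower number a stronger inhibitor. Compound 1 `CC(C)c1ccc(-c2nc(SCc3cn(CC(=O)NC(=O)Nc4ccccn4)nn3)nc(Nc3ccccc3)c2C#N)cc1` gives 14300 nM. Compound 2 `Cc1ccc(Nc2nc(SCc3cn(CC(=O)NC(=O)Nc4ccccn4)nn3)nc(-c3ccc(C(C)C)cc3)c2C#N)cc1` gives 3060 nM, and compound 3 `Cc1cccc(Nc2nc(SCc3cn(CC(=O)NC(=O)Nc4ccccn4)nn3)nc(-c3ccc(C(C)C)cc3)c2C#N)c1` gives 1650 nM. Compound 2 stands second highest of the three numbers; the nearest gap is a 1.9-fold lower number from compound 2 to compound 3 (0.27 log units; within the scatter), a difference within the scatter, while the furthest is a 4.7-fold lower number from compound 1 to compound 2 (0.67 log units; beyond the scatter). A comparable step is seen in an 8.7-fold lower number from compound 1 to compound 3 (0.94 log units; beyond the scatter).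

Compound 4 `Cc1ccc(Nc2nc(SCc3cn(CC(=O)NC(=O)Nc4ccccn4)nn3)nc(-c3ccccc3)c2C#N)cc1` differs from compound 2 by hydrogen in place of isopropyl on an aromatic carbon. Among the compounds with values here, none of the measured steps bears directly on this change: each of them concerns a methyl added to the anilino ring, and the isopropyl-bearing ring is untouched throughout. The measured data therefore give no guide to the direction or size of the step, and a change of no more than the scatter is the plainest expectation, with a wide allowance either way. The implied step, a 1.6-fold higher number from compound 2 to compound 4 (0.21 log units; within the scatter), is thus expected to be small. Compound 4 is expected to come in at about 5000 nM, within a range from 1500 nM to 20000 nM.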

Compound 4, half-maximal inhibitory concentration: 3300 nM
Estimate against measurement, compound 4: 1.5-fold (0.18 log units) above, within the range that was stated.
By their numbers in this assay, from the lowest: compounds 3, 2 and 4 (each within the scatter of the next); then compound 1.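

Within the data shown here, until compound 4, the ring bearing the isopropyl group had stayed the same in every compound, so the change from 4-isopropylphenyl to phenyl is the first reading at this place in this assay on the shared core. Replacing isopropyl with hydrogen gives a 1.1-fold higher number from compound 2 to compound 4 (0.03 log units; within the scatter) and so leaves the two compounds indistinguishable, which shows that with a 4-methylphenyl on the nitrogen, this assay does not separate the isopropyl compound from the unsubstituted phenyl compound. Nothing available explains why the two numbers match.

On these data alone, whether the same holds with the 3-methylphenyl of compound 3 or the plain phenyl on the nitrogen of compound 1 stays open. Also open, as far as these compounds go, is what an amine, a carboxylic acid or a longer alkyl chain would do on this aromatic carbon.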